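The source may hold more compounds than are shown below. What is called first, only, known or untested is meant among the compounds shown, and "the series" means these compounds.

In a functional assay on Hep 3B2 cells (Homo sapiens) for antiproliferative activity, read by MTT assay, with a stated time of 24 h, tested at 0.05 ug/mL (on this read-out lower numbers stand for a weaker effect and higher numbers for a stronger effect at the one concentration tested), the measured compounds give:

Compound 1 `Cc1c(C(=O)Nc2c(F)cc(-c3cccc(F)c3)cc2F)nc2ccc(OC(F)(F)F)cc2c1O`: 1.05%
Compound 2 `COc1ccc2nc(C(=O)Nc3ccc(-c4ccccc4)cc3)c(C)c(O)c2c1`: 1.23%
Compound 3 `Cc1c(C(=O)Nc2ccc(-c3ccccc3)cc2)nc2ccccc2c1O`: 1.68%

All three numbers sit close to zero at the single concentration tested. Compound 2 is second highest of the three, but its nearest neighbour, compound 1, lies within the scatter, and so does compound 3, so no order among them can be read from these values.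

Compound 4 `COc1ccc2nc(C(=O)Nc3ccc(-c4ccccc4)cc3)c(C)c(C(=O)O)c2c1` has not been measured in this assay. It differs from compound 2 in one place: carboxy in place of hydroxy on an aromatic carbon of the shared core, ortho to a methyl group and opposite the ring nitrogen.

Among the compounds with values here, the only step between measured compounds, a number 0.5 percentage points higher from compound 2 to compound 3 (within the scatter), concerns a different position (hydrogen in place of methoxy) and does not bear on the hydroxy-to-carboxy change. Within the data shown here, no measured pair informs the change to compound 4. With all three measured values near the floor of the read-out, and nothing to point either way, the expected step of a number 0.3 percentage points higher from compound 2 to compound 4 (within the scatter) is none beyond the scatter. Compound 4 is therefore estimated at 1.5%, within a range of -5% to 10%.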

Compound 4, a percentage reported as inhibition, at one concentration (the size of the read-out at that concentration, not a potency): 0.65%
Beside the measured number, compound 4's estimate is 0.9 percentage points above it; low and high end bracket the measured number.
By their numbers in this assay, from the lowest: compounds 4, 1, 2 and 3 (each within the scatter of the next).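

In this assay, carboxy in place of hydroxy on an aromatic carbon of the shared core, opposite the ring nitrogen, gives a number 0.6 percentage points lower from compound 2 to compound 4 (within the scatter) and so adds no step beyond the scatter, although the entering group has 3 heavy atoms against 1. Within the data shown here, with compound 4 at 0.65% as close to zero as the earlier compounds, this change at this position gives no sign of a stronger effect at the one concentration tested. No measurement available here speaks to the cause of this result.

On these data alone, whether an amine or a longer chain at this position would lift the read-out clear of the scatter remains open. Also open, as far as these compounds go, is whether compound 2 and compound 4 would separate at any other concentration or in any other cell line.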